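The source may hold more compounds than are shown below. What is called first, only, known or untested is meant among the compounds shown, and "the series" means these compounds.

Working notes on the series

Three analogues of one shared core have been run so far, all differing only in the five-membered aromatic ring attached on an aromatic carbon. Compound 1 `O=C(O)c1cc(-c2cocn2)ccc1O` gives 110 mg/kg in a functional assay on the whole organism for inhibition, with Rattus norvegicus as the target, read by paw edema; on this read-out lower numbers stand for an effect already at smaller amounts and higher numbers for an effect only at larger amounts of compound. Compound 2 `O=C(O)c1cc(-c2ccns2)ccc1O` gives 80 mg/kg in this assay, and the step of a 1.4-fold lower number from compound 1 to compound 2 (0.14 log units; within the scatter) stays within the scatter. Compound 3 `O=C(O)c1cc(-n2nccn2)ccc1O` gives 150 mg/kg in this assay; this is the highest of the three numbers, but the steps of a 1.4-fold higher number from compound 1 to compound 3 (0.13 log units; within the scatter) and a 1.9-fold higher number from compound 2 to compound 3 (0.27 log units; within the scatter) are both within the scatter, so compound 3 cannot be set apart from the other two on these data.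

Compound 4 `O=C(O)c1cc(-c2ccno2)ccc1O` is the next member. The change from compound 3 is 1,2-oxazol-5-yl in place of 2H-1,2,3-triazol-2-yl on an aromatic carbon. Every measured step in the set so far is an exchange of one five-membered aromatic ring for another at this same place, and none of the three, a 1.4-fold lower number from compound 1 to compound 2 (0.14 log units; within the scatter), a 1.4-fold higher number from compound 1 to compound 3 (0.13 log units; within the scatter) and a 1.9-fold higher number from compound 2 to compound 3 (0.27 log units; within the scatter), left the scatter. The step to compound 4 is of the same kind, so no shift beyond the scatter is expected in this assay in either direction; the estimated step is a 1.4-fold lower number from compound 3 to compound 4 (0.13 log units; within the scatter). For compound 4 the expected value in this assay is 110 mg/kg, with a range from 55 mg/kg to 220 mg/kg.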

Compound 4, dose for half-maximal effect: 110 mg/kg
Estimate against measurement, compound 4: no gap at the digits printed; the measured number falls inside the stated range.
By their numbers in this assay, from the lowest: compounds 2, 1, 4 and 3 (each within the scatter of the next).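

In this assay, the 1,2-oxazol-5-yl ring gives a 1.4-fold lower number from compound 3 to compound 4 (0.13 log units; within the scatter), a 1.4-fold higher number from compound 2 to compound 4 (0.14 log units; within the scatter) and no change at the digits printed from compound 1 to compound 4 (within the scatter), so all three new steps stay within the scatter, as did the three earlier ones. The series now shows that a ring with 2 hetero atoms and one with 3 hetero atoms cannot be told apart at this place, and the same holds for the 1,2-oxazol-5-yl and 1,2-thiazol-5-yl rings, and for the 1,2-oxazol-5-yl and 1,3-oxazol-4-yl rings, so none of the four rings can be set apart from the others on this read-out. No available evidence bears on why these ring exchanges leave the number within the scatter.

Still open, from the compounds shown here alone, is whether a group of another kind on this aromatic carbon, such as an amine or a longer alkyl chain, would move the number beyond the scatter. Also open, going by these compounds, is how the number responds to a change at the carboxy or hydroxy group, for example a methyl ester in place of the carboxylic acid, since all four compounds carry both groups unchanged.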